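Aryl swap on the triazole of a triterpenoid ester series

The source may report more compounds than this note shows. Statements on the series, on what has been measured and on what is new or still open speak of the compounds shown alone.

Three esters share a core and differ only in the aryl group on the triazole nitrogen. Compound 1 `C/C(=C\CC/C(C)=C/CC[C@@H]1[C@@]2(C)CCC(=O)C(C)(C)[C@H]2CC[C@@]1(C)O)CC/C=C(\C)C(=O)OCc1cn(-c2ccccc2Cl)nn1` carries a 2-chlorophenyl there; in a functional assay on DU-145 cells (Homo sapiens) for antiproliferative activity, read by MTT assay, with a stated time of 48 h (on this read-out lower numbers stand for stronger inhibition and higher numbers for weaker inhibition), compound 1 gives only a limit, > 150000 nM. Compound 2 `C/C(=C\CC/C(C)=C/CC[C@@H]1[C@@]2(C)CCC(=O)C(C)(C)[C@H]2CC[C@@]1(C)O)CC/C=C(\C)C(=O)OCc1cn(-c2cccc(O)c2)nn1`, with a 3-hydroxyphenyl, gives 28400 nM in this assay. Compound 3 `C/C(=C\CC/C(C)=C/CC[C@@H]1[C@@]2(C)CCC(=O)C(C)(C)[C@H]2CC[C@@]1(C)O)CC/C=C(\C)C(=O)OCc1cn(-c2ccc(Br)cc2)nn1`, with a 4-bromophenyl, likewise returns only a limit in this assay, > 150000 nM. So compound 1 sits at the same bound as compound 3; the shared bound is the limit of > 150000 nM in this assay, at which 2 of the 3 values shown sit. The step of an at least 5.2-fold lower number from compound 1 to compound 2 (0.72 log units; beyond the scatter) is the only readable one, the step of an at least 5.2-fold higher number from compound 2 to compound 3 (0.72 log units; beyond the scatter) mirrors it, and the step that the two limits leave unreadable from compound 1 to compound 3 cannot be sized.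

Compound 4 `C/C(=C\CC/C(C)=C/CC[C@@H]1[C@@]2(C)CCC(=O)C(C)(C)[C@H]2CC[C@@]1(C)O)CC/C=C(\C)C(=O)OCc1cn(-c2ccc(C)cc2)nn1` is the next member; it differs from compound 1 by 4-methylphenyl in place of 2-chlorophenyl on an aromatic nitrogen. The change keeps the count of donors and acceptors at zero, as the change to compound 3 did, and does not bring in the hydroxy group that set compound 2 apart. The bearing steps therefore give no readable size, and no step beyond the scatter is expected in this assay. Compound 4 is expected at 150000 nM with a range from 40000 nM to 500000 nM, most likely reported again as a limit, which means an expected step of a number no higher from compound 1 to compound 4 (the limit leaves the size open).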

Compound 4, half-maximal inhibitory concentration: > 150000 nM
Compound 4 was reported as a limit; the forecaster's own chance of this, stated with the estimate: 70%; the middle value sits exactly at the limit.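

With 4-methylphenyl on the triazole nitrogen, a group made only of carbon and hydrogen joins 2-chlorophenyl and 4-bromophenyl at the same assay limit, so this bound does not depend on a halogen being present: the limit of > 150000 nM in this assay, at which 3 of the 4 values shown sit.

Among these compounds, the 3-hydroxyphenyl group remains the only aryl group here that gives a measured number rather than a limit, and 4-methylphenyl in place of 3-hydroxyphenyl gives an at least 5.2-fold higher number from compound 2 to compound 4 (0.72 log units; beyond the scatter) in this assay. The steps that link the 4-methylphenyl compound to the 2-chlorophenyl and 4-bromophenyl compounds cannot be read, as both ends of each are limits, so these three aryl groups cannot be ranked against one another.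

On these data alone, it remains open whether the difference seen with compound 2 follows from the hydroxy group itself or from where it sits on the phenyl ring. A 4-hydroxyphenyl, a 3-aminophenyl or a 3-methoxyphenyl on the same nitrogen would bear on that question, and each could show whether a second measured number can be obtained in this series.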